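The source may report more compounds than this note shows. Statements on the series, on what has been measured and on what is new or still open speak of the compounds shown alone.

Measured so far:
Compound 1 `O=C1Nc2ccccc2/C1=N/NC(=S)Nc1ccccc1` gives > 25000 nM in an ADME assay on RD cells (Homo sapiens) for cytotoxicity (a lower number here means that less compound is tolerated, a higher number that more compound is tolerated), which is a limit of the assay rather than a number.
Compound 2 `COc1ccccc1NC(=S)N/N=C1\C(=O)Nc2ccccc21` gives > 25000 nM in this assay, also a limit.
Compound 3 `O=C1Nc2ccc(F)cc2/C1=N/NC(=S)Nc1ccccc1` gives > 25000 nM in this assay, again a limit.

Compound 1 therefore stands only at a limit, and the two other values are limits as well. The steps away from compound 1 are a step that the two limits leave unreadable from compound 1 to compound 2 and a step that the two limits leave unreadable from compound 1 to compound 3; both sizes stay hidden because of the limit of > 25000 nM in this assay, at which 3 of the 3 values shown sit. Compound 4 `O=C1/C(=N\NC(=S)Nc2ccccc2)c2ccccc2N1Cc1ccccc1` differs from compound 1 by benzyl in place of hydrogen on an amide-type nitrogen in a ring. The two measured steps concern other places and read as nothing, so in this assay no step beyond the scatter is expected for compound 4, and the estimated step is a number no higher from compound 1 to compound 4 (the limit leaves the size open). Compound 4 is expected to give about 25000 nM, in a range from 8000 nM to 60000 nM.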

Compound 4, half-maximal cytotoxic concentration: > 25000 nM
Compound 4: a limit, no number (the forecaster's own chance of this, stated with the estimate: 70%); the middle value sits exactly at the limit.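

Compound 4 and compound 1 both sit at a limit of the assay rather than at a number, so no step can be read between them: the limit of > 25000 nM in this assay, at which 4 of the 4 values shown sit. The compounds shown leave open whether benzyl, methoxy or fluoro changes the result in this assay at all.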